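Swapping the 4-cyanophenyl group of compound 2

The source may hold more compounds than are shown below. What is called first, only, known or untested is meant among the compounds shown, and "the series" means these compounds.

Compound 1 `COc1ccc(OC)c(/C=C/C(=O)Nc2cc3c(Nc4ccc(F)c(Cl)c4)ncnc3cc2OC)c1` gives 34300 nM
Compound 2 `N#Cc1ccc(/C=C/C(=O)Nc2cc3c(Nc4ccc(F)c(Cl)c4)ncnc3cc2O[C@H]2CCOC2)cc1` gives 9830 nM
Compound 3 `COc1cc2ncnc(Nc3ccc(F)c(Cl)c3)c2cc1NC(=O)/C=C/c1ccc(C#N)cc1` gives "not active" (no number reported)

All three were tested in a functional assay on MCF7 cells (Homo sapiens) for cytotoxicity, read by MTT assay, with a stated time of 72 h; a lower number here means a stronger inhibitor, a higher number a weaker inhibitor. Compound 2 holds the lower of the two numbers, and its gap to compound 1 lies beyond the scatter. Compound 3 gives no number.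

The unmeasured compound 4 `COc1cc(/C=C/C(=O)Nc2cc3c(Nc4ccc(F)c(Cl)c4)ncnc3cc2O[C@H]2CCOC2)cc(OC)c1O` departs from compound 2 in one group, with 4-hydroxy-3,5-dimethoxyphenyl in place of 4-cyanophenyl on a double-bonded chain carbon bound to a double-bonded chain carbon. Within the data shown here, no measured pair isolates this swap, so any forecast in this assay is loose. Compound 1 also bears methoxy groups on the ring at this place and gives 34300 nM, but it differs from compound 2 elsewhere too. No step beyond the scatter is expected, though a move either way remains possible. The expected step is a 1.2-fold higher number from compound 2 to compound 4 (0.09 log units; within the scatter). For compound 4 the estimated value is 12000 nM, with an expected range from 4000 nM to 38000 nM.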

Compound 4, half-maximal inhibitory concentration: 30500 nM
Compound 4: middle estimate off by 2.5-fold (0.41 log units), on the low side, within the range that was stated.
By their numbers in this assay, from the lowest: compound 2; then compounds 4 and 1 (each within the scatter of the next).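

In this assay, among these compounds, the pair of compounds that differ only in this group gives the first clean reading of the place on a double-bonded chain carbon bound to a double-bonded chain carbon. Putting 4-hydroxy-3,5-dimethoxyphenyl in place of 4-cyanophenyl gives a 3.1-fold higher number from compound 2 to compound 4 (0.49 log units; beyond the scatter), so the number does respond to the group carried here, and this swap gives up part of the modest cytotoxic activity of compound 2. No measurement at hand explains the step.

The compounds shown leave open whether the hydroxy group, the methoxy groups or the loss of the nitrile accounts for the step, which a plain 4-hydroxyphenyl or 3,5-dimethoxyphenyl group at this place could begin to separate. They also leave open how an amine or a carboxylic acid on the ring would read here.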